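The source may report more compounds than this note shows. Statements on the series, on what has been measured and on what is new or still open speak of the compounds shown alone.

Compound 1 `CC(C)=CCC/C(C)=C/CC/C(C)=C/CSC[C@H](NC(=O)CCCCCN1CCN(C)CC1)C(=O)NC1CCCCCC1`: 2700 nM
Compound 2 `CC(C)=CCC/C(C)=C/CC/C(C)=C/CSC[C@H](NC(=O)CCCCCN1CCCC1)C(=O)NC1CCCC1`: 3200 nM

For the measured compounds named here, in a functional assay on MIA PaCa-2 cells (Homo sapiens) for cytotoxicity, read by fluorescence, with a stated time of 48 h (on this read-out higher numbers stand for an effect only at larger amounts of compound and lower numbers for an effect already at smaller amounts), compound 2 gives 3200 nM, a number within the usual scatter of the one for compound 1. Compound 3 `CC(C)=CCC/C(C)=C/CC/C(C)=C/CSC[C@H](NC(=O)CCCCCN1CCCC1)C(=O)NC1CCCCCC1` differs from compound 2 in one place, with cycloheptyl in place of cyclopentyl on an amide-type nitrogen. Going by the values given here, no measured pair shows this change alone. Compound 1 also carries cycloheptyl and gives 2700 nM, so no step beyond the scatter is expected. The estimated 1.1-fold lower number from compound 2 to compound 3 (0.06 log units; within the scatter) is expected to stay within the scatter. For compound 3 the expected value is 2800 nM, with an estimated range of 1500 nM to 5000 nM.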

Compound 3, half-maximal effective concentration: 6800 nM
The estimate for compound 3 lay 2.4-fold (0.39 log units) below the measured number, outside the stated range (above it).
By their numbers in this assay, from the lowest: compounds 1 and 2 (each within the scatter of the next); then compound 3.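

In this assay the carbon ring on the amide-type nitrogen does affect the number: cycloheptyl in place of cyclopentyl gives a 2.1-fold higher number from compound 2 to compound 3 (0.33 log units; beyond the scatter) with the rest of the molecule unchanged. With cycloheptyl held fixed, the amine on the chain counts as well, since pyrrolidin-1-yl in place of 4-methylpiperazin-1-yl gives a 2.5-fold higher number from compound 1 to compound 3 (0.40 log units; beyond the scatter) in the same assay. Nothing shown here gives a reason for either step. Still open, going by these compounds, is where cyclohexyl on that nitrogen would fall, and how morpholine or dimethylamino would read in place of pyrrolidin-1-yl.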